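The compounds below may be only part of what the source reports. "The series", "measured", "known", "first", "only" and "open" are said of these compounds alone.

Measured in a functional assay on MGC-803 cells (Homo sapiens) for antiproliferative activity, read by CellTiter-Glo, with a stated time of 72 h; a lower number here means a stronger inhibitor, a higher number a weaker inhibitor:
compound 1 `O=C(NO)c1ccc(/C=C/c2ccnc(-c3ccc(F)cc3)c2)cc1`: > 10000 nM
compound 2 `O=C(NO)c1ccc(/C=C/c2ccnc(-c3ccc(C(F)(F)F)cc3)c2)cc1`: > 10000 nM

Both entries are limits, not numbers. Compound 2 gives > 10000 nM, so it stands with the whole series at the limit of > 10000 nM in this assay, at which 2 of the 2 values shown sit.

Compound 3 `COc1ccc(-c2cc(/C=C/c3ccc(C(=O)NO)cc3)ccn2)cc1` carries methoxy in place of trifluoromethyl on an aromatic carbon, para to a large group: methoxy in place of trifluoromethyl on an aromatic carbon.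

Going by the values given here, the only measured guide is a step that the two limits leave unreadable from compound 1 to compound 2, which offers no size to carry over. In this assay, no expected change goes beyond the scatter, and no direction is favoured: the expected step is a number no higher from compound 2 to compound 3 (the limit leaves the size open). The expected value for compound 3 is 10000 nM, with an estimated range of 3000 nM to 30000 nM.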

Compound 3, half-maximal inhibitory concentration: 3510 nM
Compound 3: middle estimate off by 2.8-fold (0.45 log units), on the high side, within the range that was stated.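

Methoxy on this aromatic carbon, para to a large group, gives the first number of the series in this assay and shows that a change at this position can shift the read-out. The steps are an at least 2.8-fold lower number from compound 2 to compound 3 (0.45 log units; beyond the scatter) with methoxy replacing trifluoromethyl and an at least 2.8-fold lower number from compound 1 to compound 3 (0.45 log units; beyond the scatter) with methoxy replacing fluoro. Both sizes are floors, since compounds 1 and 2 give limits and not numbers: the limit of > 10000 nM in this assay, at which 2 of the 3 values shown sit.

The step between compounds 1 and 2 cannot be read. From the compounds shown here alone, whether an amine, a hydroxyl or a longer chain such as ethoxy on this carbon would match or exceed methoxy remains open.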